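The source may hold more compounds than are shown below. What is called first, only, known or untested is meant among the compounds shown, and "the series" means these compounds.

Working notes on the series in a toxicity assay on MDCK cells (Canis lupus familiaris) for cytotoxicity, read by crystal violet staining, with a stated time of 48 h; a higher number here means that more compound is tolerated, a lower number that less compound is tolerated.

Compound 1 `Cc1ccc2[nH]c(=O)c(CN(Cc3ccc(OCC(=O)O)cc3)Cc3ccc(C(C)(C)C)cc3)cc2c1` and compound 2 `COc1ccc(CN(Cc2ccc(C(C)(C)C)cc2)Cc2cc3cc(C)ccc3[nH]c2=O)cc1` share the core with compound 3 `Cc1ccc2[nH]c(=O)c(CN(Cc3ccc(OC(F)(F)F)cc3)Cc3ccc(C(C)(C)C)cc3)cc2c1` and differ only in the group on the oxygen on the aromatic ring. In this assay compound 1 gives > 10000 nM, which is a limit of the assay and not a number. Compound 2 likewise gives > 10000 nM, again a limit. Compound 3 gives > 5000 nM, also a limit. Accordingly the steps a step that the two limits leave unreadable from compound 1 to compound 2, a step that the two limits leave unreadable from compound 1 to compound 3 and a step that the two limits leave unreadable from compound 2 to compound 3 cannot be read in size; what can be said is given by the limit of > 10000 nM in this assay, at which 2 of the 3 values shown sit, and (the limit of > 5000 nM in this assay, at which 1 of the 3 values shown sits), so compound 3 stands at a limit like the two others, with no value placing it apart from them.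

Compound 4 `Cc1ccc2[nH]c(=O)c(CN(Cc3ccc(C(C)(C)C)cc3)[C@@H](C)c3ccc(F)cc3)cc2c1` is reached from compound 3 by 1-(4-fluorophenyl)ethyl in place of 4-(trifluoromethoxy)benzyl on an amine nitrogen. Within the data shown here, no measured step alters the amine substituent in this way, so none bears directly on the change; the three measured steps all sit at limits and show no readable movement in this assay. The expectation is therefore a step that the limit leaves unreadable from compound 3 to compound 4 from compound 3 to compound 4, with no movement beyond the scatter anticipated. Compound 4 is estimated at 10000 nM, in the range 4000 nM to 25000 nM, most probably reported again as a limit.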

Compound 4, half-maximal cytotoxic concentration: > 5000 nM
Compound 4: no number, only a limit; the forecaster's own chance of this, stated with the estimate: 80%; the middle value is on the limit's open side.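

In this assay compound 4 gives > 5000 nM, a limit of the assay and not a number. The steps from compound 1, compound 2 and compound 3 to compound 4 therefore cannot be read in size. The compounds shown leave open where any of the four would reach a half-maximal cytotoxic concentration, and whether the substituent on the amine nitrogen alters it: the limit of > 5000 nM in this assay, at which 2 of the 4 values shown sit.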